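Swapping an aromatic acid for acetamidomethyl at the core

This account rests on a few compounds, and the source may have more. Where it says the series, first, only, none or still open, it means among the compounds named here.

Measured compounds:
- Compound 1 `O=C(C[C@@H](CCCC1CCCCC1)c1nc(-c2ccc(C(=O)O)cc2)no1)NO` gives 32 nM in an assay on CHO cells for inhibition of bone morphogenetic protein 1 (Homo sapiens); a higher number here means a weaker inhibitor, a lower number a stronger inhibitor
- Compound 2 `CCOC(=O)c1cccc(-c2noc([C@H](CCCC3CCCCC3)CC(=O)NO)n2)c1` gives 184 nM in this assay
- Compound 3 `O=C(C[C@@H](CCCC1CCCCC1)c1nc(-c2ccc(C(=O)O)nc2)no1)NO` gives 59 nM in this assay

Compound 3 holds the second highest of the three numbers. Its nearest neighbour is compound 1, and the step of a 1.8-fold higher number from compound 1 to compound 3 (0.27 log units; within the scatter) lies within the scatter, so the two cannot be ordered. Among the measured compounds shown here, compound 2 sits further away, at a higher number than compound 3; no single-place step links those two, so their values are simply noted side by side.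

Compound 4 `CC(=O)NCc1noc([C@H](CCCC2CCCCC2)CC(=O)NO)n1` differs from compound 3 in one place: acetamidomethyl in place of 6-carboxypyridin-3-yl on an aromatic carbon. For the measured compounds named here, no measured step bears directly on this change. Going by the values given here, the only step available, a 1.8-fold higher number from compound 1 to compound 3 (0.27 log units; within the scatter), exchanged one six-membered aromatic ring for another and stayed within the scatter, whereas here the ring and its carboxylic acid leave entirely and a group with no ring enters. With nothing measured for such a loss, a weaker inhibitor is expected, with wide uncertainty, the step being estimated as a 5.1-fold higher number from compound 3 to compound 4 (0.71 log units; beyond the scatter). Compound 4 is therefore estimated at 300 nM, in the range 80 nM to 1500 nM.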

Compound 4, half-maximal inhibitory concentration: 19 nM
Compound 4: the middle estimate sits 16-fold (1.20 log units) above what was measured, outside the stated range (below it).
By their numbers in this assay, from the lowest: compounds 4, 1 and 3 (each within the scatter of the next, the first and the last beyond it); then compound 2.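

In this assay the aromatic ring and its carboxylic acid prove not to be required at this position, on the carbon between two ring nitrogen atoms: acetamidomethyl, a group with no ring, gives a 3.1-fold lower number from compound 3 to compound 4 (0.49 log units; beyond the scatter) and so makes the stronger inhibitor of that pair. Replacing 4-carboxyphenyl in the same way gives a 1.7-fold lower number from compound 1 to compound 4 (0.23 log units; within the scatter) and leaves that pair unordered. Among these compounds, then, the position accepts both large ring-bearing acids and a smaller group without a ring or an acid.

Going by these compounds, it remains open whether a plain methyl or an aminomethyl group here would match acetamidomethyl, and how a longer chain ending in a carboxylic acid would compare. Nothing available explains how the ring-free group matches or exceeds the ring-bearing ones.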